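The compounds below may be only part of what the source reports. "The series", "measured", "known", "first", "only" and "open" are said of these compounds alone.

Of the compounds shown here, three have so far been measured in an ADME assay on SW480 cells (Homo sapiens) for cytotoxicity, read by MTT assay, with a stated time of 72 h; on this read-out lower numbers stand for stronger inhibition and higher numbers for weaker inhibition. Compound 1 `Cc1ccc(N2C(=O)C/C(=C\c3cccc(C(=O)Nc4cccc(F)c4)c3)C2=O)cc1` gives 96900 nM. Compound 2 `CCCCCN1C(=O)C/C(=C\c2cccc(C(=O)Nc3cccc(CC)c3)c2)C1=O` gives 83300 nM, and compound 3 `CCc1cccc(NC(=O)c2cccc(/C=C3\CC(=O)N(c4ccccc4)C3=O)c2)c1` gives 88600 nM. Compound 3 thus stands second highest of the three numbers, with compound 2 nearest and compound 1 furthest, and all three values lie within the scatter of one another. For the measured compounds named here, the only single-point step among them, a 1.1-fold higher number from compound 2 to compound 3 (0.03 log units; within the scatter), consisted of phenyl in place of pentyl on an amide-type nitrogen in a ring.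

Compound 4 `O=C(Nc1ccc(Cl)cc1)c1cccc(/C=C2\CC(=O)N(c3ccccc3)C2=O)c1` has not yet been measured. It differs from compound 3 by 4-chlorophenyl in place of 3-ethylphenyl on an amide-type nitrogen. Going by the values given here, no measured step touches this amide-type nitrogen, so the step from compound 2 to compound 3 bears on the question only by showing that a change elsewhere in the molecule left the read-out within the scatter; compounds 1 and 2 differ in two places, and their values also sit within the scatter of each other. With nothing pointing in either direction, the account expects a step of a 1.0-fold higher number from compound 3 to compound 4 (0.01 log units; within the scatter), that is, none beyond the scatter. Compound 4 is therefore estimated at 90000 nM, with a range from 45000 nM to 180000 nM.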

Compound 4, half-maximal inhibitory concentration: > 100000 nM
Compound 4: a limit, no number; the forecaster's own chance of this, stated with the estimate: 15%; at least 1.1-fold (0.04 log units) between middle value and limit.
By their numbers in this assay, from the lowest: compounds 2, 3 and 1 (each within the scatter of the next). At a limit, above all of these: compound 4.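

In this assay compound 4 gives > 100000 nM, which is a limit of the assay and not a number. The change from 3-ethylphenyl to 4-chlorophenyl is the first single change shown on this amide-type nitrogen, and it gives an at least 1.1-fold higher number from compound 3 to compound 4 (0.05 log units; that floor lies within the scatter), so this swap brought no lower number, while the true size of the step stays unknown. Unlike the earlier compounds, which all carry numbers, compound 4 is the one case in this series where the read-out ends without a number: the limit of > 100000 nM in this assay, at which 1 of the 4 values shown sits.

The compounds shown leave open whether the chlorine or its place on the phenyl ring matters more, as the step changes both at once, and a 3-chlorophenyl or a 4-ethylphenyl group on this amide-type nitrogen would separate the two. From the compounds shown here alone, whether an amine or a carboxylic acid on that phenyl ring would bring the number down, so that a change at this position could be read as a full step, also remains open.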